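The compounds below may be only part of what the source reports. "The series", "measured", "known", "first", "only" and "open" are said of these compounds alone.

Compound 2, `CCc1cccc2c(=O)c(-c3nn[nH]n3)c[nH]c12`, was tested in a functional assay on the whole organism (strain Sprague-Dawley) for inhibition, with Rattus norvegicus as the target; on this read-out higher numbers stand for an effect only at larger amounts of compound and lower numbers for an effect already at smaller amounts. In this assay compound 2 returns only a limit, > 25 mg/kg, and so sits at the limit of > 25 mg/kg in this assay, at which 1 of the 2 values shown sits, rather than at a number. Compound 1, `CCc1cccc2cc(C(=O)O)cnc12`, gives 75 mg/kg in this assay. Compound 3, `O=c1c(-c2nn[nH]n2)c[nH]c2c(Br)cccc12`, differs from compound 2 by bromo in place of ethyl on an aromatic carbon. Among the compounds with values here, with no measured step to lean on, the expected step that the limit leaves unreadable from compound 2 to compound 3 in this assay is taken as none beyond the scatter. Compound 3 is therefore estimated at 40 mg/kg in this assay, within a range from 15 mg/kg to 150 mg/kg, with a fair chance that only a limit is reported again.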

Compound 3, minimum effective dose: > 10 mg/kg
Compound 3: a limit, no number (the forecaster's own chance of this, stated with the estimate: 60%); the middle value does not contradict the limit.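

Within the data shown here, compound 2 and compound 3 both return only limits in this assay, and no step between them can be read. Going by these compounds, whether bromo in place of ethyl on an aromatic carbon shifts the minimum effective dose at all remains open.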